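A few compounds are considered here, and "the series" means these few. Any claim that something is new, unique, unknown or untested is made for them only; others in the source may bear on it.

Compound 1 `COc1ccc(OC)c2ncc(-c3nn[nH]n3)cc12` sits at a limit of the assay in a functional assay on the whole organism (strain Sprague-Dawley) for inhibition, with Rattus norvegicus as the target; a higher number here means that more compound is needed for the effect, a lower number that less compound is needed: compound 1 gives > 50 mg/kg.
Compound 2 `Cc1ccc2cc(C(=O)O)cnc2c1C` gives a number in this assay: compound 2 gives 50 mg/kg.
Compound 3 `COc1ccc(OC)c2ncc(C(=O)O)cc12` also sits at a limit in this assay: compound 3 gives > 50 mg/kg.

Going by the values given here, compound 2 thus carries the only number among the three; the other two values are limits, as the limit of > 50 mg/kg in this assay, at which 2 of the 3 values shown sit, records. From compound 3 to compound 1 the change is 2H-tetrazol-5-yl in place of carboxy on an aromatic carbon, and in this assay it gives a step that the two limits leave unreadable from compound 3 to compound 1. The same change is made from compound 2 to the unmeasured compound 4 `Cc1ccc2cc(-c3nn[nH]n3)cnc2c1C`: 2H-tetrazol-5-yl in place of carboxy on an aromatic carbon. The difference between the cores of compound 2 and compound 3 is not broken down here. Because the step from compound 3 to compound 1 is a step that the two limits leave unreadable from compound 3 to compound 1, the measured pair gives no size to carry over. The expectation for compound 4 therefore rests on compound 2 with its 50 mg/kg, and the step from compound 2 to compound 4 is expected to be about no change at the digits printed from compound 2 to compound 4 (within the scatter). Compound 4 is estimated at 50 mg/kg, expected to lie between 20 mg/kg and 120 mg/kg, with a real chance that only a limit is reported.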

Compound 4, minimum effective dose: 25 mg/kg
Estimate against measurement, compound 4: 2.0-fold (0.30 log units) above; measured number inside the range.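

The exchange of carboxy for 2H-tetrazol-5-yl gives a 2.0-fold lower number from compound 2 to compound 4 (0.30 log units; within the scatter) in this assay and so, on this one core, leaves the minimum effective dose within the usual scatter. The same exchange on the other core cannot be read, and it offers no size to set against this step, because compound 3 and compound 1 both stand at a limit: the limit of > 50 mg/kg in this assay, at which 2 of the 4 values shown sit. The result therefore shows that the two groups cannot be told apart on one core in this assay, but it does not show that the change carries over to the other core with the same size, or that the two cores respond alike.

It remains open whether an amide or a methyl ester on the same aromatic carbon would give a dose in the same range as the two groups shown. On these data alone, it also remains open whether any group on the core of compound 1 would give a number rather than a limit.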